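Removing a Trifluoromethyl Group from an Inactive Compound

The compounds below may be only part of what the source reports. "The series", "measured", "known", "first", "only" and "open" are said of these compounds alone.

Measured so far in a functional assay on A549 cells (Homo sapiens) for antiproliferative activity, read by MTT assay, with a stated time of 72 h; a higher number here means a weaker inhibitor, a lower number a stronger inhibitor:
- compound 1 `O=[N+]([O-])c1ccc(COc2cccc(Nc3ncnc4cc5c(cc34)OCCOCCOCCOCCO5)c2)cc1`: 19800 nM
- compound 2 `FC(F)(F)c1ccc(COc2cccc(Nc3ncnc4cc5c(cc34)OCCOCCO5)c2)cc1`: > 100000 nM (a limit, not a number)

Going by the values given here, compound 1 at 19800 nM provides the only actual number here, so it offers just a rough scale for what a measurable result may look like.

Compound 2 has no exact value, and its result is a limit of the assay: the limit of > 100000 nM in this assay, at which 1 of the 2 values shown sits.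

The next compound to be tested is compound 3 `c1ccc(COc2cccc(Nc3ncnc4cc5c(cc34)OCCOCCO5)c2)cc1`. It has hydrogen in place of trifluoromethyl on an aromatic carbon, so 4-(trifluoromethyl)benzyl becomes benzyl: hydrogen in place of trifluoromethyl on an aromatic carbon.

Among the compounds with values here, no measured pair shows what this change does in this assay, so any forecast is uncertain. A modest move toward stronger inhibition is expected, though the result could remain at the limit. The expected change is an at least 1.8-fold lower number from compound 2 to compound 3 (0.25 log units; that floor lies within the scatter).

For compound 3 the estimated value is 55000 nM, with an expected range from 18000 nM to 100000 nM.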

Compound 3, half-maximal inhibitory concentration: 7590 nM
Beside the measured number, compound 3's estimate is 7.2-fold (0.86 log units) above it, and the stated range ends above it.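

The trifluoromethyl group on the benzyl ring turns out to matter a great deal: in this assay, replacing it with hydrogen gives an at least 13-fold lower number from compound 2 to compound 3 (1.11 log units; beyond the scatter). Going by these compounds alone, until now, this position had no measured step, and nothing showed whether a change there could bring this core into a measurable range. With the plain benzyl group, compound 3 reaches 7590 nM, so this core can inhibit the growth of these cells without any group at that ring carbon, and the trifluoromethyl group is not needed for this activity. Going by these compounds, the true size of the step remains unknown because the result for compound 2 is a limit, not a number: the limit of > 100000 nM in this assay, at which 1 of the 3 values shown sits.

A single pair cannot show whether a fluorine atom, a methoxy group or an amine at this ring carbon would behave more like hydrogen or more like trifluoromethyl. On these data alone, it also remains open whether the same change would have a similar effect on the core of compound 1, which differs from compound 3 in more than one place and so cannot be compared with it directly.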